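Extending the Unsaturated Chain on a Shared Core

This account rests on a few compounds, and the source may have more. Where it says the series, first, only, none or still open, it means among the compounds named here.

In a functional assay (trachea) with Cavia porcellus as the target (a lower number here means that less compound is needed, a higher number that more compound is needed for the effect), compound 1 `CCCn1c(=O)n(CC)c(=O)c2[nH]cnc21` gives 1300 nM and compound 2 `C=CCn1c(=O)c2[nH]cnc2n(CCC)c1=O` gives 1600 nM within the scatter of compound 1. Compound 3 `C=CCCn1c(=O)c2[nH]cnc2n(CCC)c1=O` differs from compound 2 by allyl in place of vinyl on a saturated chain carbon bound to an aromatic nitrogen in a change that reads allyl in place of vinyl on a saturated chain carbon bound to an aromatic nitrogen. Among the measured compounds shown here, the only measured step that bears on this, a 1.2-fold higher number from compound 1 to compound 2 (0.09 log units; within the scatter) for vinyl in place of methyl at that place, lies within the scatter, so no step beyond the scatter is expected in this assay here. Compound 3 is estimated at 1300 nM within a range of 500 nM to 3200 nM in this read-out. The expected change is a 1.2-fold lower number from compound 2 to compound 3 (0.09 log units; within the scatter) by this estimate.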

Compound 3, half-maximal effective concentration: 200 nM
Estimate against measurement, compound 3: 6.5-fold (0.81 log units) above, and the stated range ends above it.
By their numbers in this assay, from the lowest: compound 3; then compounds 1 and 2 (each within the scatter of the next).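

At this place on the shared core, chain length now shows up in this assay: allyl in place of vinyl brings an 8.0-fold lower number from compound 2 to compound 3 (0.90 log units; beyond the scatter), whereas the earlier change of vinyl in place of methyl stayed within the scatter. Vinyl in place of hydrogen on a saturated chain carbon, two bonds along the chain from an aromatic nitrogen, brings a 6.5-fold lower number from compound 1 to compound 3 (0.81 log units; beyond the scatter), so compound 3 stands apart from the other two. Nothing at hand gives a reason for these steps. The compounds shown leave open whether a saturated butyl chain here would match compound 3, which would weigh the double bond itself. They also leave open whether a longer chain would extend the step.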